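The source may hold more compounds than are shown below. What is called first, only, known or untested is meant among the compounds shown, and "the series" means these compounds.

Going by the values given here, compound 2, `CCOC(=O)C1=C(C)NC(C)=C(C(=O)OCC)C1c1ccc(OCC(=O)Nc2c(C)cccc2C)cc1`, gives 26.3% in a functional assay on the whole organism (strain Wistar) for inhibition, with Rattus norvegicus as the target, read by paw edema, with stated times of 30 min and 1 h, at a dose of 20 mg/kg (on this read-out lower numbers stand for less inhibition and higher numbers for more inhibition at the one dose given (going by the name of the read-out)), the higher of the two numbers so far. Compound 1, `CCOC(=O)C1=C(C)NC(C)=C(C(=O)OCC)C1c1ccc(OCC(=O)NCc2ccccc2)cc1`, gives 16.1%, and the step of a number 10.2 percentage points higher from compound 1 to compound 2 (beyond the scatter) shows that the group on the amide-type nitrogen matters. Compound 3, `CCOC(=O)C1=C(C)NC(C)=C(C(=O)OCC)C1c1ccc(OCC(=O)Nc2ccc(C)cc2)cc1`, differs from compound 2 by 4-methylphenyl in place of 2,6-dimethylphenyl on an amide-type nitrogen. Among the compounds with values here, no measured step exchanges one substituted phenyl for another, so the only guide is that the benzyl-to-aryl change was modest. A small drop or no step beyond the scatter is therefore expected, a number 6.3 percentage points lower from compound 2 to compound 3 (within the scatter). Compound 3 is estimated at 20%, within 8% to 32%.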

Compound 3, a percentage reported as inhibition, in the whole organism at one dose (the size of the read-out at that dose, not a potency): 55.1%
The estimate for compound 3 lay 35.1 percentage points below the measured number; measured number outside the range, above it.
By their numbers in this assay, from the lowest: compound 1; then compound 2; then compound 3.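

In this assay, putting 4-methylphenyl in place of 2,6-dimethylphenyl on the amide-type nitrogen gives a number 28.8 percentage points higher from compound 2 to compound 3 (beyond the scatter), and putting it in place of benzyl gives a number 39 percentage points higher from compound 1 to compound 3 (beyond the scatter). So an aryl group at this position is not enough in itself: two methyl-bearing phenyl groups on the same nitrogen give clearly different results, and this change outweighs the earlier step from benzyl. No measurement here explains this difference. Going by these compounds, it remains open whether plain phenyl, 4-chlorophenyl or 4-methoxyphenyl on this nitrogen would match compound 3 .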